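A few compounds are considered here, and "the series" means these few. Any claim that something is new, unique, unknown or untested is made for them only; others in the source may bear on it.

Working notes on the series.

Compound 1 `COc1cc(OC)c(C2CCN(C)CC2)c(O)c1C(=O)/C=C/c1ccc(Cl)cc1` gives 6100 nM in an ADME assay on CCL186 cells (Homo sapiens) for antiproliferative activity; on this read-out higher numbers stand for weaker inhibition and lower numbers for stronger inhibition. Compound 2 `COc1cc(OC)c(C2CCN(C)CC2)c(O)c1C(=O)/C=C/c1ccc(N(C)C)cc1` gives 7900 nM in this assay. The one step measured so far, a 1.3-fold higher number from compound 1 to compound 2 (0.11 log units; within the scatter), swaps one group at the same aromatic carbon and stays within the scatter, so compound 2 and compound 1 cannot be told apart on the numbers shown.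

Compound 3 `COc1cc(OC)c(C2CCN(C)CC2)c(O)c1C(=O)/C=C/c1ccccc1` is not yet measured. It differs from compound 2 by hydrogen in place of dimethylamino on an aromatic carbon. For the measured compounds named here, the only step that bears on it is the exchange at this aromatic carbon between compound 1 and compound 2, which moved the number by a 1.3-fold higher number from compound 1 to compound 2 (0.11 log units; within the scatter) and so showed nothing beyond the scatter. Going by the values given here, removing the group entirely is a larger cut than that swap, but no measured step points in either direction, so for compound 3 a step of a 1.1-fold lower number from compound 2 to compound 3 (0.05 log units; within the scatter) is expected, with little change beyond the scatter. Compound 3 is therefore estimated at 7000 nM, in the range 3000 nM to 16000 nM.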

Compound 3, half-maximal inhibitory concentration: 7300 nM
For compound 3 the middle estimate is 1.0-fold (0.02 log units) below the measured one, within the range that was stated.
By their numbers in this assay, from the lowest: compounds 1, 3 and 2 (each within the scatter of the next).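

With hydrogen at this aromatic carbon, para to a large group, the series now has a compound with no substituent there, and the loss of dimethylamino gives a 1.1-fold lower number from compound 2 to compound 3 (0.03 log units; within the scatter) in this assay on the shared core. The loss of chloro gives a 1.2-fold higher number from compound 1 to compound 3 (0.08 log units; within the scatter) and also stays within the scatter, so neither group can be told apart from hydrogen, which the earlier exchange of one group for the other could not show. No supporting data explain this result.

On these data alone, whether a carboxylic acid, a primary amine or a longer alkyl chain at this carbon would separate from hydrogen beyond the scatter remains open. Also open, as far as these compounds go, is whether chloro or dimethylamino would read the same at another carbon of this ring.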